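Swapping the Aryl Group on a Weakly Antiproliferative Scaffold

This account rests on a few compounds, and the source may have more. Where it says the series, first, only, none or still open, it means among the compounds named here.

Compound 1, `CCC1=C(O)c2c(oc(-c3cccc(F)c3)cc2=O)C(CC)(CC)C1=O`, gives in a functional assay on KB cells (Homo sapiens) for antiproliferative activity, read by sulforhodamine B assay, with a stated time of 3 days (a higher number here means that more compound is needed for the effect, a lower number that less compound is needed), only a limit of > 56.2 uM.
Compound 2, `CCC1=C(O)c2c(oc(-c3ccccc3C)cc2=O)C(CC)(CC)C1=O`, gives in this assay a value of 40.9 uM.

Going by the values given here, compound 2 thus holds the only actual number in this small set; the other entry is a limit, not a measurement. Among the compounds with values here, the step of an at least 1.3-fold lower number from compound 1 to compound 2 (0.13 log units; that floor lies within the scatter) is the sole measured change, and it rests on (the limit of > 56.2 uM in this assay, at which 1 of the 2 values shown sits), so its true size is unknown and its floor lies within the scatter.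

Compound 3, `CCC1=C(O)c2c(oc(-c3ccc(OC)c(C)c3)cc2=O)C(CC)(CC)C1=O`, carries the change (4-methoxy-3-methylphenyl in place of 2-methylphenyl on an aromatic carbon). Within the data shown here, no measured step touches the 4-methoxy-3-methylphenyl group, and the one step available says little about how the aryl group sets the number. The step from compound 2 to compound 3 is therefore expected to be small, a 1.2-fold lower number from compound 2 to compound 3 (0.07 log units; within the scatter), with wide uncertainty in either direction. For compound 3 the estimated value in this assay is 35 uM, within a range from 10 uM to 110 uM.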

Compound 3, concentration for half-maximal effect: 28.5 uM
Compound 3: the middle estimate sits 1.2-fold (0.09 log units) above what was measured; the range from low to high includes it.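

Two measured numbers can now be set side by side at this aryl position, next to the ring oxygen, and in this assay the step is a 1.4-fold lower number from compound 2 to compound 3 (0.16 log units; within the scatter). Replacing 2-methylphenyl with 4-methoxy-3-methylphenyl adds heavy atoms and a hydrogen-bond acceptor, yet the two values cannot be told apart. The other step, an at least 1.9-fold lower number from compound 1 to compound 3 (0.29 log units; that floor lies within the scatter), is only a floor, since one of its ends is a limit and not a number: the limit of > 56.2 uM in this assay, at which 1 of the 3 values shown sits.

The compounds shown leave open whether any aryl group here can shift the number beyond the scatter, and whether the methoxy or the methyl of compound 3 counts for anything on its own. They also do not tell what an amine, a carboxylic acid or a longer chain would do at this position.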